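Demethylation of compound 2: notes on the series

This account rests on a few compounds, and the source may have more. Where it says the series, first, only, none or still open, it means among the compounds named here.

Numbers in an ADME assay on MCF7 cells for inhibition of cytochrome P450 26A1 (Homo sapiens) (on this read-out higher numbers stand for weaker inhibition and lower numbers for stronger inhibition), so far:
compound 1 `COc1ccc2c(c1)CC/C(=C\c1ccccc1C)C2=O` gives 20000 nM
compound 2 `COc1ccc2c(c1)CC/C(=C\c1ccccc1Br)C2=O` gives 9000 nM
compound 3 `COc1ccc2c(c1)CC/C(=C\c1ccc(O)cc1)C2=O` gives 7000 nM

Compound 2 holds the second highest number of the three in this assay: compound 1 sits above it, a 2.2-fold lower number from compound 1 to compound 2 (0.35 log units; beyond the scatter), while compound 3 lies within the scatter of it, a 1.3-fold lower number from compound 2 to compound 3 (0.11 log units; within the scatter). Compound 4 `O=C1/C(=C/c2ccccc2Br)CCc2cc(O)ccc21` differs from compound 2 by hydrogen in place of methyl on an oxygen on an aromatic ring. For the measured compounds named here, no measured step touches that oxygen; the two steps known for compound 2, a 2.2-fold lower number from compound 1 to compound 2 (0.35 log units; beyond the scatter) and a 1.3-fold lower number from compound 2 to compound 3 (0.11 log units; within the scatter), both concern the phenyl group, not the methoxy, and were modest at most. Going by the values given here, with no precedent for this change in this assay, the expected step is no change at the digits printed from compound 2 to compound 4 (within the scatter), not clearly beyond the scatter. The estimate for compound 4 in this assay is 9000 nM, range 3000 nM to 27000 nM.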

Compound 4, half-maximal inhibitory concentration: 20000 nM
Estimate against measurement, compound 4: 2.2-fold (0.35 log units) below; measured number inside the range.
By their numbers in this assay, from the lowest: compounds 3 and 2 (each within the scatter of the next); then compounds 1 and 4 (each within the scatter of the next).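

In this assay, for the compounds shown here, hydrogen in place of methyl on an oxygen on an aromatic ring gives a 2.2-fold higher number from compound 2 to compound 4 (0.35 log units; beyond the scatter) and so shows that this position, untouched by the earlier steps, affects the read-out. The hydroxy compound reads as the weaker inhibitor of the pair, though the step is modest and remains the only one at this oxygen. Nothing shown accounts for this step.

Open, from the compounds shown here alone, is whether ethoxy or an amine at this place would stay with compound 2 or with compound 4. Also open, going by these compounds, is whether methoxy to hydroxy gives a similar step with the other phenyl groups.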